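This account rests on a few compounds, and the source may have more. Where it says the series, first, only, none or still open, it means among the compounds named here.

Measured compounds:
compound 1 `CCOC(=O)c1cccc(-c2ccc(OCC)cc2)c1` — 87%
compound 2 `CCOC(=O)c1cccc(-c2ccc(O)cc2)c1` — 77%

In an assay on COS-7 cells for inhibition of patatin-like phospholipase domain-containing protein 2 (Mus musculus), tested at 200 uM (on this read-out higher numbers stand for more inhibition at the one concentration tested (going by the name of the read-out) and lower numbers for less inhibition), compound 1 gives 87% and compound 2 gives 77%. Compound 2 stands at the lower of the two numbers, though the step of a number 10 percentage points lower from compound 1 to compound 2 (within the scatter) is within the scatter.

Compound 3 `CCOC(=O)c1cccc(-c2ccc(OC)cc2)c1` differs from compound 2 by methyl in place of hydrogen on an oxygen on an aromatic ring. Among the compounds with values here, the one measured step that bears on this is a number 10 percentage points lower from compound 1 to compound 2 (within the scatter), so compound 3 is expected to sit close to both, with a step of a number 5 percentage points higher from compound 2 to compound 3 (within the scatter) that is expected to stay within the scatter. Compound 3 is therefore estimated at 82%, with a range from 68% to 94%.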

Compound 3, a percentage reported as inhibition, at one concentration (the size of the read-out at that concentration, not a potency): 77%
Compound 3: the middle estimate sits 5 percentage points above what was measured; low and high end bracket the measured number.
By their numbers in this assay, from the lowest: compounds 2, 3 and 1 (each within the scatter of the next).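

In this assay, the hydroxy to methoxy change on this oxygen on an aromatic ring gives no change at the digits printed from compound 2 to compound 3 (within the scatter), while replacing the ethyl on the same oxygen with methyl gives a number 10 percentage points lower from compound 1 to compound 3 (within the scatter). Hydrogen, methyl and ethyl at this position thus all lie within the scatter of one another, so none of these changes separates the compounds. No evidence on the cause accompanies these numbers.

Still open, from the compounds shown here alone, is whether a longer chain on this oxygen, or an amine or a carboxylic acid in place of the whole group, would give a step beyond the scatter.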